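Replacing a methyl with a hydroxy on a nitrobenzofurazan aniline

A few compounds are considered here, and "the series" means these few. Any claim that something is new, unique, unknown or untested is made for them only; others in the source may bear on it.

Measured so far:
compound 1, `O=[N+]([O-])c1ccc(Nc2ccccc2)c2nonc12`, 2%
compound 2, `Cc1ccccc1Nc1ccc([N+](=O)[O-])c2nonc12`, 11%
compound 3, `Cc1ccc(Nc2ccc([N+](=O)[O-])c3nonc23)cc1`, 0%

In an assay on isolated protein for inhibition of Myc proto-oncogene protein (Homo sapiens), read by mobility shift assay, tested at 100 uM (a higher number here means more inhibition at the concentration tested (going by the name of the read-out), a lower number less inhibition), compound 3 gives the lowest of the three numbers, though its gap to compound 1 lies within the scatter; only compound 2 stands beyond it. Compound 4 is `O=[N+]([O-])c1ccc(Nc2ccc(O)cc2)c2nonc12`; it differs from compound 3 in one place: hydroxy in place of methyl on an aromatic carbon. Within the data shown here, no measured step swaps a methyl for a hydroxy, so the closest guides are a number 2 percentage points lower from compound 1 to compound 3 (within the scatter) and a number 9 percentage points higher from compound 1 to compound 2 (within the scatter), both small changes on the same six-membered ring of carbon only. With nothing in the data pointing to a large effect, the step of a number 3 percentage points higher from compound 3 to compound 4 (within the scatter) is expected to stay within the scatter. Compound 4 is therefore estimated at 3%, with a range from -7% to 13%.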

Compound 4, a percentage reported as inhibition, at one concentration (the size of the read-out at that concentration, not a potency): 0%
For compound 4 the middle estimate is 3 percentage points above the measured one; the range from low to high includes it.
By their numbers in this assay, from the lowest: compounds 3, 4, 1 and 2 (each within the scatter of the next, the first and the last beyond it).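

At this place, para to a large group, this assay shows hydroxy in place of methyl giving (no change at the digits printed from compound 3 to compound 4 (within the scatter)), and hydroxy in place of hydrogen giving (a number 2 percentage points lower from compound 1 to compound 4 (within the scatter)). Adding one hydrogen-bond donor and one acceptor at this place therefore leaves the reading within the scatter. No supporting evidence bears on this result. On these data alone, whether an amine or a carboxylic acid here would read differently remains open. So does whether a hydroxy would match the methyl of compound 2 at its place on the ring.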